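This account rests on a few compounds, and the source may have more. Where it says the series, first, only, none or still open, it means among the compounds named here.

In a functional assay on PC-3 cells (Homo sapiens) for inhibition, read by MTT assay (a higher number here means a weaker inhibitor of growth, a lower number a stronger inhibitor of growth), compound 1 (`CC1=C(/C=C/C(C)=C/C=C/C(C)=C\C(=O)Nc2ccccc2)C(C)(C)CCC1n1ccnc1`) gives 8910 nM, and compound 2 (`CC1=C(/C=C/C(C)=C/C=C/C(C)=C\C(=O)Nc2ccc(O)cc2)C(C)(C)CCC1n1ccnc1`) gives 11700 nM. Compound 2 therefore stands within the scatter of compound 1, and these two numbers are the only ones available for the series. The next compound is compound 3 (`CC1=C(/C=C/C(C)=C/C=C/C(C)=C\C(=O)Nc2cccc(F)c2)C(C)(C)CCC1n1ccnc1`), which keeps the shared core and carries 3-fluorophenyl in place of 4-hydroxyphenyl on an amide-type nitrogen. For the measured compounds named here, only one measured step bears on this change, hydroxy in place of hydrogen on an aromatic carbon, which amounts to a 1.3-fold higher number from compound 1 to compound 2 (0.12 log units; within the scatter). That step covers the loss of the hydroxy, and it suggests that this loss should matter little. Going by the values given here, no measured step shows what fluorine does on this ring, so that part of the change remains unknown and widens the range. A shift beyond the scatter is not expected in this assay, though a slightly lower number is the likelier direction. The estimate means a 1.5-fold lower number from compound 2 to compound 3 (0.17 log units; within the scatter), an expected step that stays within the scatter. For compound 3 the expected value is 8000 nM, with an estimated range of 3500 nM to 16000 nM.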

Compound 3, concentration for 50% growth inhibition: 5620 nM
Compound 3: the middle estimate sits 1.4-fold (0.15 log units) above what was measured; the measured number falls inside the stated range.
By their numbers in this assay, from the lowest: compounds 3, 1 and 2 (each within the scatter of the next, the first and the last beyond it).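

In this assay, for the compounds shown here, replacing 4-hydroxyphenyl with 3-fluorophenyl on the amide-type nitrogen gives a 2.1-fold lower number from compound 2 to compound 3 (0.32 log units; beyond the scatter), the first step in this small set to pass beyond the usual scatter, though only modestly. Read alone, fluoro in place of hydrogen on an aromatic carbon gives a 1.6-fold lower number from compound 1 to compound 3 (0.20 log units; within the scatter), so, like the hydroxy step, it does not set the substituted compound apart from the unsubstituted compound 1; the only separation seen lies between the two substituted compounds, compound 2 and compound 3. Nothing available accounts for that separation.

As far as these compounds go, what a methoxy, an amine or a carboxylic acid on this aromatic ring would do remains open, as does whether a second fluoro would extend the small step seen with the first. Also open, from the compounds shown here alone, is whether a group other than a substituted phenyl on the amide-type nitrogen, such as a longer alkyl chain, would stay close to these compounds in this assay.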